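The compounds below may be only part of what the source reports. "The series", "measured", "known", "first", "only" and "open" are said of these compounds alone.

Measured compounds:
- Compound 1, `CC(C)(C)OC(=O)CN(Cc1ccc([N+](=O)[O-])cc1)Cc1ccc([N+](=O)[O-])s1`: 2500 nM
- Compound 2, `O=C(O)CN(Cc1ccc(Cl)cc1)Cc1ccc([N+](=O)[O-])s1`: "not determined" (no result reported)

Compound 1 was tested in a functional assay on HEK293 cells for agonist activity at nuclear receptor subfamily 1 group D member 1 (Homo sapiens), read by a luciferase reporter, with a stated time of 24 h (a higher number here means that more compound is needed for the effect, a lower number that less compound is needed), and gives 2500 nM. Compound 2 shares the same core but carries a carboxylic acid on the chain and a chloro group on the phenyl ring; in this assay compound 2 has "not determined" (no result reported), so there is no number for it to stand on. The two compounds also differ in two places, so nothing can be read from them as a single step.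

Compound 3, `N#CCN(Cc1ccc(Cl)cc1)Cc1ccc([N+](=O)[O-])s1`, has not been measured yet. It differs from compound 2 by cyano in place of carboxy on a saturated chain carbon bound to an amine nitrogen. With no measured step for this change, and no number for compound 2, the size and direction of the step cannot be taken from the data shown; it could lie within the scatter or beyond it in either direction.

Within the data shown here, the only anchor is compound 1 with 2500 nM, a compound that also lacks a free acid on the chain. On that basis compound 3 is expected to give about 3000 nM in this assay, with a range from 800 nM to 12000 nM.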

Compound 3, half-maximal effective concentration: 2500 nM
For compound 3 the middle estimate is 1.2-fold (0.08 log units) above the measured one, within the range that was stated.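

In this assay, no new step can be read for compound 3: compound 2 has "not determined" (no result reported), and compound 1 differs from compound 3 in more than one place. The compounds shown leave open what replacing carboxy with cyano does to the result in this assay. No supporting evidence bears on this result.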